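A few compounds are considered here, and "the series" means these few. Any claim that something is new, unique, unknown or untested is made for them only; others in the source may bear on it.

Two compounds have numbers in an assay on isolated protein for inhibition of DNA topoisomerase 1 (Homo sapiens), with a stated time of 30 min, tested at 100 uM; on this read-out higher numbers stand for more inhibition at the one concentration tested (going by the name of the read-out) and lower numbers for less inhibition. Compound 1 `Clc1ccc(-c2cc(-c3ccco3)cc(-c3ccc(Cl)s3)n2)cc1` gives 53.1% in this assay. Compound 2 `Cc1cccc(-c2cc(-c3ccoc3)cc(-c3ccc(Cl)s3)n2)c1` gives 2.6% in this assay, the lower of the two numbers, and the gap to compound 1 lies beyond the usual scatter of such measurements. Compound 3 `Clc1ccc(-c2cc(-c3ccoc3)cc(-c3ccc(Cl)s3)n2)cc1` has not yet been measured in this assay. It differs from compound 2 in one place: 4-chlorophenyl in place of 3-methylphenyl on an aromatic carbon. Among the compounds with values here, no step between two measured compounds matches this change, so nothing measured tells directly what it does. Compound 3 carries the 4-chlorophenyl group that compound 1 also carries, and compound 1 gives 53.1%; it carries the furan-3-yl group that compound 2 also carries, and compound 2 gives 2.6%. Nothing shows which of these groups sets the number, and the estimate for compound 3 is placed between the two. The expected step is a number 22.4 percentage points higher from compound 2 to compound 3 (beyond the scatter), upward and beyond the scatter. Compound 3 is expected to give about 25% in this assay, within a range from 0% to 55%.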

Compound 3, a percentage reported as inhibition, at one concentration (the size of the read-out at that concentration, not a potency): 2.3%
The estimate for compound 3 lay 22.7 percentage points above the measured number; the range from low to high includes it.
By their numbers in this assay, from the lowest: compounds 3 and 2 (each within the scatter of the next); then compound 1.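

In this assay, 4-chlorophenyl in place of 3-methylphenyl on the aromatic carbon next to the ring nitrogen comes with a number 0.3 percentage points lower from compound 2 to compound 3 (within the scatter), so with furan-3-yl held in place, this exchange does not separate the two compounds. The other single change, furan-3-yl in place of furan-2-yl, comes with a number 50.8 percentage points lower from compound 1 to compound 3 (beyond the scatter), which shows that the point of attachment of the furan matters greatly here and that the 4-chlorophenyl group alone does not preserve the number of compound 1. No supporting data are available to explain either result.

It remains open whether 3-methylphenyl and 4-chlorophenyl would also read alike alongside furan-2-yl, since their exchange is shown only with furan-3-yl, so the finding for this position may not carry over to the furan-2-yl series. From the compounds shown here alone, it is also open how the read-out at this one concentration would respond if a thiophen-2-yl group or a morpholine took the place of the furan, or if an amine or a carboxylic acid stood on the phenyl ring.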